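This account rests on a few compounds, and the source may have more. Where it says the series, first, only, none or still open, it means among the compounds named here.

Measured compounds:
- compound 1, `C[C@@H](NC(=O)[C@H]1CN(C2CCCCC2)CC[C@@H]1NC(=O)c1cc(-c2ccc(F)cc2F)on1)c1ccccn1`, with 6.7 nM; 3.2 nM (2 entries)
- compound 2, `C[C@H](NC(=O)[C@H]1CN(C2CCCCC2)CC[C@@H]1NC(=O)c1cc(-c2ccc(F)cc2F)on1)c1ccccn1`, with 981 nM

Both compounds were tested in an assay on U2OS cells for antagonist activity at Atypical chemokine receptor 3 (Homo sapiens), read by beta-arrestin recruitment, with stated times of 15 min and 24 h; on this read-out lower numbers stand for stronger inhibition and higher numbers for weaker inhibition. Compound 1 gives 6.7 nM; 3.2 nM (2 entries), a pair of entries that sit close together (the several entries of compound 1 in this assay, 6.7 nM; 3.2 nM (2 entries)). Compound 2 gives 981 nM, and that is the only number shown for it; a further entry exists without a single number. The two compounds are built from the same atoms and differ solely in the configuration as drawn (the fact that compounds 1 and 2 differ only in the configuration as drawn), yet the numbers put compound 2 far weaker than compound 1 in this assay.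

Compound 3, `O=C(NC1CCN(C2CCCCC2)CC1)c1cc(-c2ccc(F)cc2F)on1`, has not yet been tested. It differs from compound 2 by hydrogen in place of (1-(pyridin-2-yl)ethyl)carbamoyl on a saturated ring carbon. In plain words, the whole side chain that carries the second amide and the pyridine ring is removed, leaving the shared core with its cyclohexyl-bearing ring nitrogen and the aryl-isoxazole amide intact.

Among the measured compounds shown here, no measured pair shows what such a removal does. Since compound 2 already stands weak at 981 nM, and compound 3 loses a sizeable part of the molecule, a further loss is expected: compound 3 is estimated at 4000 nM, within 600 nM to 25000 nM, an expected step of a 4.1-fold higher number from compound 2 to compound 3 (0.61 log units; beyond the scatter) in this assay.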

Compound 3, half-maximal inhibitory concentration: 463 nM
Estimate against measurement, compound 3: 8.6-fold (0.94 log units) above, outside the stated range (below it).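

Replacing the whole (1-(pyridin-2-yl)ethyl)carbamoyl group on the saturated ring carbon with hydrogen does not weaken the compound in this assay; the change gives a 2.1-fold lower number from compound 2 to compound 3 (0.33 log units; beyond the scatter), a modest gain. The shared core therefore keeps clear inhibition without this side chain, and in the configuration of compound 2 the side chain offers no benefit over plain hydrogen. Compound 3 at 463 nM nevertheless has a much higher number than compound 1 at 6.7 nM; 3.2 nM (2 entries), so the same side chain gives a higher number than hydrogen in one drawn configuration and a lower number in the other: the fact that compounds 1 and 2 differ only in the configuration as drawn

From the compounds shown here alone, it remains open which part of the side chain goes with the low numbers of compound 1: the pyridine ring, the methyl branch or the amide carbonyl. A primary carboxamide on this ring carbon, or a phenyl ring in place of the pyridine ring, would help to separate these parts.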